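Adding fluorines to the benzyl group of compound 2

This account rests on a few compounds, and the source may have more. Where it says the series, first, only, none or still open, it means among the compounds named here.

Measured so far in a functional assay on A-375 cells (Homo sapiens) for antiproliferative activity (on this read-out lower numbers stand for stronger inhibition and higher numbers for weaker inhibition), as follows:
- compound 1 `O=C(Nc1ccc(-c2cscn2)cc1)C1CCCN(C(=O)c2ccc(F)c(F)c2)C1` gives > 20000 nM (a limit, not a number)
- compound 2 `O=C(Nc1ccc(-c2cscn2)cc1)C1CCCN(Cc2ccc(F)cc2)C1` gives 2250 nM

Within the data shown here, compound 2 at 2250 nM holds the only true number so far. Compound 3 `O=C(Nc1ccc(-c2cscn2)cc1)C1CCCN(Cc2cc(F)c(F)c(F)c2)C1` differs from it as follows: 3,4,5-trifluorophenyl in place of 4-fluorophenyl on a saturated chain carbon bound to an amine nitrogen in a ring. Among the measured compounds shown here, the one measured step, an at least 8.8-fold lower number from compound 1 to compound 2 (0.94 log units; beyond the scatter), replaced the whole group on the amine nitrogen in a ring. It gives no direct measure of a change in fluorine count alone, so no step beyond the scatter is expected in this assay here. The expected step is a 1.1-fold lower number from compound 2 to compound 3 (0.05 log units; within the scatter) and remains a rough estimate. For compound 3 the estimate is 2000 nM with an expected range of 700 nM to 6500 nM in this series.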

Compound 3, half-maximal inhibitory concentration: 400 nM
The estimate for compound 3 lay 5.0-fold (0.70 log units) above the measured number, and the stated range ends above it.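

With the 4-fluorobenzyl link held on the amine nitrogen in a ring, changing only the aryl group moves the number in this assay: a 5.6-fold lower number from compound 2 to compound 3 (0.75 log units; beyond the scatter). Against the carbonyl-linked compound 1, the change reads an at least 50-fold lower number from compound 1 to compound 3 (1.69 log units; beyond the scatter). The value of compound 1 is a limit, not a number, so that step has no fixed size: the limit of > 20000 nM in this assay, at which 1 of the 3 values shown sits.

Going by these compounds, with only these two benzyl compounds, it remains open whether the step follows the fluorine count or one particular fluorine. On these data alone, it is also open whether chlorine or a nitrile on the phenyl ring would act like fluorine.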